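The source may report more compounds than this note shows. Statements on the series, on what has been measured and on what is new or still open speak of the compounds shown alone.

Values in a functional assay on NCI-H460 cells (Homo sapiens) for cytotoxicity, read by MTT assay, with a stated time of 72 h; a higher number here means a weaker inhibitor, a lower number a stronger inhibitor:
- Compound 1 `O=c1[nH]/c(=C\c2c[nH]cn2)c(=O)[nH]/c1=C\c1cccc(Oc2ccc(F)cc2)c1`: 479 nM
- Compound 2 `O=c1[nH]/c(=C\c2ccco2)c(=O)[nH]/c1=C\c1cccc(Oc2ccc(F)cc2)c1`: 155 nM
- Compound 3 `O=c1[nH]/c(=C\c2ccc(Br)o2)c(=O)[nH]/c1=C\c1cccc(Oc2ccc(F)cc2)c1`: 361 nM

Compound 3 cannot be told apart from compound 1, a 1.3-fold lower number from compound 1 to compound 3 (0.12 log units; within the scatter), but stands clear of compound 2, a 2.3-fold higher number from compound 2 to compound 3 (0.37 log units; beyond the scatter). Compound 4 `O=c1[nH]/c(=C\c2cc3ccccc3o2)c(=O)[nH]/c1=C\c1cccc(Oc2ccc(F)cc2)c1` follows from 1-benzofuran-2-yl in place of 5-bromofuran-2-yl on a double-bonded chain carbon bound to an aromatic carbon. Two modest steps bear on this change: the bromo step just given, and a 3.1-fold lower number from compound 1 to compound 2 (0.49 log units; beyond the scatter), for furan-2-yl in place of 1H-imidazol-4-yl. Going by the values given here, no measured step covers the added six-membered aromatic ring. Compound 4 has no bromine, so a partial return towards compound 2 at 155 nM is expected. The expected step, a 1.4-fold lower number from compound 3 to compound 4 (0.16 log units; within the scatter), is small and stays within the scatter. For compound 4 the estimated value is 250 nM, with an expected range from 100 nM to 600 nM.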

Compound 4, half-maximal inhibitory concentration: 347 nM
Compound 4: the middle estimate sits 1.4-fold (0.14 log units) below what was measured; low and high end bracket the measured number.
By their numbers in this assay, from the lowest: compound 2; then compounds 4, 3 and 1 (each within the scatter of the next).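

In this assay, 1-benzofuran-2-yl at this place cannot be told apart from 5-bromofuran-2-yl, a 1.0-fold lower number from compound 3 to compound 4 (0.02 log units; within the scatter), or from 1H-imidazol-4-yl, a 1.4-fold lower number from compound 1 to compound 4 (0.14 log units; within the scatter). Against furan-2-yl it gives a higher number, a 2.2-fold higher number from compound 2 to compound 4 (0.35 log units; beyond the scatter), so the added six-membered aromatic ring, like the bromo group, goes with a weaker result than the plain furan-2-yl of compound 2. No measured evidence explains this. The compounds shown leave open whether a smaller group such as methyl, or an amine or a carboxylic acid, in place of the bromo group would keep the number of compound 2 or lower it.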